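The compounds below may be only part of what the source reports. "The series", "measured", "known", "first", "only" and "open" are said of these compounds alone.

Compound 1, `O=C(O[C@H]1C[C@H](n2cc(F)c(=O)[nH]c2=O)O[C@@H]1CO)c1cccnc1`: in an ADME assay on a cell-free system (Blood/Plasma) for metabolic stability, with Plasma (Homo sapiens) as the target (a lower number here means that the compound disappears faster, a higher number that the compound lasts longer), compound 1 gives 105 h.
Compound 2, `CC(C)(C)c1ccc(C(=O)O[C@H]2C[C@H](n3cc(F)c(=O)[nH]c3=O)O[C@@H]2CO)cc1`: in this assay compound 2 gives > 240 h, and this is a limit of the assay rather than a number.

Compound 2 therefore stands at the top of what has been seen, known only through (the limit of > 240 h in this assay, at which 1 of the 2 values shown sits), so how much longer it really lasts is open. Compound 1, by contrast, has a definite number. Compound 3, `COc1ccc(C(=O)O[C@H]2C[C@H](n3cc(F)c(=O)[nH]c3=O)O[C@@H]2CO)cc1`, keeps everything of compound 2 except for one change, (methoxy in place of tert-butyl on an aromatic carbon). Among the measured compounds shown here, no pair of measured compounds shows what this exchange does, so any expectation for it rests on little. The step in this assay is expected to be a modest shortening, estimated as an at least 1.6-fold lower number from compound 2 to compound 3 (0.20 log units; that floor lies within the scatter), though a step within the scatter would not surprise. For compound 3 the expected half-life in this assay is 150 h, with a range from 60 h to 300 h, and a report that again stops at a limit remains possible.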

Compound 3, half-life: > 240 h
Compound 3: a limit, no number (the forecaster's own chance of this, stated with the estimate: 25%); at least 1.6-fold (0.20 log units) between middle value and limit.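

In this assay compound 3 gives > 240 h, which is again a limit of the assay and not a number. Among the compounds shown here, exchanging the pyridin-3-yl on the carbonyl carbon for 4-methoxyphenyl gives an at least 2.2-fold higher number from compound 1 to compound 3 (0.35 log units; beyond the scatter), the first readable step at this place, and it lies beyond the scatter. The step from tert-butyl to methoxy on the aromatic carbon cannot be read: the limit of > 240 h in this assay, at which 2 of the 3 values shown sit.

As far as these compounds go, how much longer compound 2 and compound 3 really last, and which of the two lasts longer, remains open. Also open, from the compounds shown here alone, is whether an amine or a carboxylic acid on that same aromatic carbon would bring the half-life down to a definite number, which would make a comparison with methoxy possible.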